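The source may report more compounds than this note shows. Statements on the series, on what has been measured and on what is new or still open speak of the compounds shown alone.

Measured compounds:

Compound 1, `CC1(C)[C@H]2CC[C@]1(C)N(Cc1cn(-c3ccccc3O)nn1)C(=O)C2`: 90 nM
Compound 2, `COc1ccc(-n2cc(CN3C(=O)C[C@@H]4CC[C@@]3(C)C4(C)C)nn2)cc1`: 250 nM
Compound 3, `Cc1ccc(-n2cc(CN3C(=O)C[C@@H]4CC[C@@]3(C)C4(C)C)nn2)cc1`: 40 nM

The three share one core and differ only in the group carried on an aromatic nitrogen. In a functional assay on OVCAR-3 cells (Homo sapiens) for inhibition, read by MTT assay, with a stated time of 24 h (a higher number here means a weaker inhibitor, a lower number a stronger inhibitor), compound 3 gives the lowest number of the three; the step of a 2.3-fold lower number from compound 1 to compound 3 (0.35 log units; beyond the scatter) and the step of a 6.3-fold lower number from compound 2 to compound 3 (0.80 log units; beyond the scatter) both lie beyond the scatter, so compound 3 is the strongest inhibitor among them in this assay.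

Compound 4, `CC1(C)[C@H]2CC[C@]1(C)N(Cc1cn(-c3ccc(F)cc3)nn1)C(=O)C2`, is not yet measured. It differs from compound 3 by fluoro in place of methyl on an aromatic carbon.

Going by the values given here, the only measured step at this same aromatic carbon is a 6.3-fold lower number from compound 2 to compound 3 (0.80 log units; beyond the scatter), where methyl in place of methoxy gave a modest change. Among the compounds with values here, no fluoro analogue has been measured, and the steps of a 2.8-fold higher number from compound 1 to compound 2 (0.44 log units; beyond the scatter) and a 2.3-fold lower number from compound 1 to compound 3 (0.35 log units; beyond the scatter) concern a different part of the phenyl ring, so they speak to this change only indirectly. The exchange of one single heavy atom for another at the same place is therefore expected to give at most a small step in this assay, more likely toward a somewhat higher number than a lower one, and possibly none beyond the scatter.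

For compound 4 the expected value is 60 nM, with a range from 25 nM to 150 nM, which means an expected step of a 1.5-fold higher number from compound 3 to compound 4 (0.18 log units; within the scatter).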

Compound 4, half-maximal inhibitory concentration: 200 nM
Compound 4: middle estimate off by 3.3-fold (0.52 log units), on the low side, and the stated range ends below it.
By their numbers in this assay, from the lowest: compound 3; then compound 1; then compounds 4 and 2 (each within the scatter of the next).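

In this assay, the fluoro compound shows that exchanging one heavy atom at this aromatic carbon can move the number by a clear margin: the methyl-to-fluoro change (a 5.0-fold higher number from compound 3 to compound 4 (0.70 log units; beyond the scatter)) is of the same order as the methoxy-to-methyl change (a 6.3-fold lower number from compound 2 to compound 3 (0.80 log units; beyond the scatter)). Fluoro and methoxy cannot be told apart at this carbon (a 1.3-fold lower number from compound 2 to compound 4 (0.10 log units; within the scatter)), so among the three groups placed here, only methyl stands out, with the lowest number. Against the 2-hydroxyphenyl group of compound 1, the 4-fluorophenyl group also gives a weaker inhibitor (a 2.2-fold higher number from compound 1 to compound 4 (0.35 log units; beyond the scatter)), as the 4-methoxyphenyl group does, and only the 4-methylphenyl group gives a stronger one. Nothing available here accounts for the gap between methyl and fluoro.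

The compounds shown leave open whether a longer chain such as ethyl, or a chloro group or an amine, at this aromatic carbon would behave like methyl or like fluoro. They also leave open whether the same order of these groups would hold in other cell lines.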